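Sulfoximine in place of a fluorinated alcohol on the shared core

This account rests on a few compounds, and the source may have more. Where it says the series, first, only, none or still open, it means among the compounds named here.

Measured compounds:
compound 1, `CC#C[C@H]1CN(S(=O)(=O)c2ccc(N)nc2)CCN1c1ccc(C(O)(CC#N)C(F)(F)F)cc1`, 219 nM
compound 2, `CC#C[C@H]1CN(S(=O)(=O)c2ccc(N)nc2)CCN1c1ccc(S(=O)(=O)NC)cn1`, 381 nM
compound 3, `CC#C[C@H]1CN(S(=O)(=O)c2ccc(N)nc2)CCN1c1ncc(C(C)(O)C(F)(F)F)s1`, only a limit in this assay

Three compounds that share one core are measured in an assay on cells (Hepatocyte) for inhibition of glucokinase regulatory protein (Mus musculus), with stated times of 20 min and 40 min; on this read-out lower numbers stand for an effect already at smaller amounts and higher numbers for an effect only at larger amounts of compound. Compound 1 gives 219 nM, the lowest of the two numbers reported, while compound 2 gives 381 nM, a value that lies within the scatter of compound 1, so neither can be placed above the other. For compound 3 the assay reports only a limit, > 12500 nM, and not a number; this is the limit of > 12500 nM in this assay, at which 1 of the 3 values shown sits.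

Compound 4, `CC#C[C@H]1CN(S(=O)(=O)c2ccc(N)nc2)CCN1c1ccc(S(=O)(=NC)C(F)(F)F)cc1`, has not been measured. It differs from compound 1 by a group of 8 heavy atoms (2 carbon, 1 nitrogen, 1 oxygen, 3 fluorine, 1 sulfur; no ring) in place of a group of 9 heavy atoms (4 carbon, 1 nitrogen, 1 oxygen, 3 fluorine; no ring), on an aromatic carbon. For the measured compounds named here, no measured pair traces a change of this kind, so no step can be read off as a guide. The step is expected to stay small, with the number for compound 4 somewhat higher than for compound 1, a shift estimated as a 1.8-fold higher number from compound 1 to compound 4 (0.26 log units; within the scatter). Compound 4 is therefore estimated at 400 nM, in a range from 120 nM to 1500 nM.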

Compound 4, half-maximal effective concentration: 2060 nM
The estimate for compound 4 lay 5.2-fold (0.71 log units) below the measured number, and the stated range ends below it.
By their numbers in this assay, from the lowest: compounds 1 and 2 (each within the scatter of the next); then compound 4. At a limit, above all of these: compound 3.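

The position on the aromatic carbon, para to a large group, proves sensitive to this exchange even though the two groups are close in heavy-atom count: in this assay the change gives a 9.4-fold higher number from compound 1 to compound 4 (0.97 log units; beyond the scatter). For the compounds shown here, it is the first step that can be read on this core, and it shows that the sulfoximine does not stand in for the fluorinated alcohol without loss on this read-out. The group that leaves carries a hydrogen-bond donor and the one that enters carries none, but nothing measured here explains the step.

The compounds shown leave open whether that donor or the rest of the group accounts for the step, since no pair changes one alone. A sulfoximine with an unsubstituted nitrogen or a carboxylic acid at this position would bear on that question.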